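Swapping the Amide Aryl Group: Methoxy Gives Way to Nitro

The source may hold more compounds than are shown below. What is called first, only, known or untested is meant among the compounds shown, and "the series" means these compounds.

Of the compounds shown here, three built on one shared core have been tested in a functional assay on HepG2 cells (Homo sapiens) for antiproliferative activity, read by CCK-8 assay, with a stated time of 72 h; on this read-out higher numbers stand for weaker inhibition and lower numbers for stronger inhibition. Compound 1 `Cc1ccc(C(=O)Nc2cccc(-c3oc4cc(-c5ccc(F)cc5)ccc4c(=O)c3O)c2)cc1` carries a 4-methylphenyl on the carbonyl carbon and gives 2320 nM. Compound 2 `COc1ccccc1C(=O)Nc1cccc(-c2oc3cc(-c4ccc(F)cc4)ccc3c(=O)c2O)c1` carries a 2-methoxyphenyl in that place and gives 14500 nM, while compound 3 `Cc1cc(C)cc(C(=O)Nc2cccc(-c3oc4cc(-c5ccc(F)cc5)ccc4c(=O)c3O)c2)c1` carries a 3,5-dimethylphenyl and gives 13400 nM. Compound 2 and compound 3 lie within the scatter of each other (a 1.1-fold lower number from compound 2 to compound 3 (0.03 log units; within the scatter)), and both stand well apart from compound 1 (a 6.3-fold higher number from compound 1 to compound 2 (0.80 log units; beyond the scatter) and a 5.8-fold higher number from compound 1 to compound 3 (0.76 log units; beyond the scatter)).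

Compound 4 `O=C(Nc1cccc(-c2oc3cc(-c4ccc(F)cc4)ccc3c(=O)c2O)c1)c1ccc([N+](=O)[O-])cc1` is the next step from compound 2: 4-nitrophenyl in place of 2-methoxyphenyl on a carbonyl carbon. For the measured compounds named here, only one measured step bears directly on this change, the move from compound 1 to compound 2 (a 6.3-fold higher number from compound 1 to compound 2 (0.80 log units; beyond the scatter)), and compound 4 reverses it in part by returning to a phenyl ring that, like the 4-methylphenyl of compound 1, carries a single group. That step was modest but beyond the scatter, so a modest lowering of the number is expected for compound 4, estimated as a 2.9-fold lower number from compound 2 to compound 4 (0.46 log units; beyond the scatter). The nitro group is new to this set, so the estimate is wide: compound 4 is expected to give about 5000 nM, with a range from 1500 nM to 16000 nM.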

Compound 4, half-maximal inhibitory concentration: 1860 nM
Estimate against measurement, compound 4: 2.7-fold (0.43 log units) above; the range from low to high includes it.
By their numbers in this assay, from the lowest: compounds 4 and 1 (each within the scatter of the next); then compounds 3 and 2 (each within the scatter of the next).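

In this assay, the 4-nitrophenyl group gives a clearly lower number than two of the earlier groups, with a 7.8-fold lower number from compound 2 to compound 4 (0.89 log units; beyond the scatter) and a 7.2-fold lower number from compound 3 to compound 4 (0.86 log units; beyond the scatter). Nitro in place of methyl on the same ring makes no measurable difference, with a 1.2-fold lower number from compound 1 to compound 4 (0.10 log units; within the scatter), so these two groups cannot be told apart at this place. Across the four compounds, the 4-methylphenyl and 4-nitrophenyl amides sit together at the low end and the 2-methoxyphenyl and 3,5-dimethylphenyl amides at the high end, with no compound going against this split, but no measurement given here explains it.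

From the compounds shown here alone, it remains open whether a 4-methoxyphenyl would join compound 1 and compound 4 or stay with compound 2, which would show whether the higher number goes with the methoxy group itself or with its place on the ring. Also open, going by these compounds, is how a 4-aminophenyl, a 4-carboxyphenyl or a plain phenyl ring would read, and whether any of them would fall clearly below compound 1 and compound 4.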